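Propyl on the amide-type nitrogen of compound 2

The source may report more compounds than this note shows. Statements on the series, on what has been measured and on what is new or still open speak of the compounds shown alone.

In an ADME assay on Ava5 cells (Homo sapiens) for cytotoxicity (a higher number here means that more compound is tolerated, a lower number that less compound is tolerated), compound 1 `NC(=S)Nc1cccc(OCCCCc2ccccc2)c1` gives > 50000 nM as a limit of the assay, not a number. Compound 2 `NC(=S)Nc1cccc(OCCCCCc2ccccc2)c1` gives 22000 nM and compound 3 `NC(=S)Nc1cccc(OCCCCCCc2ccccc2)c1` gives 28000 nM as numbers within the scatter of each other. Among the measured compounds shown here, compound 2 therefore stands level with compound 3, and it is one of only two compounds here with a number rather than a limit. Compound 4 `CCCNC(=S)Nc1cccc(OCCCCCc2ccccc2)c1` carries propyl in place of hydrogen on an amide-type nitrogen as propyl in place of hydrogen on an amide-type nitrogen. The measured steps change the chain and leave that nitrogen untouched, so they gauge size only. With an at least 2.2-fold lower number from compound 1 to compound 2 (0.35 log units; beyond the scatter) as one measured step and a 1.3-fold higher number from compound 2 to compound 3 (0.10 log units; within the scatter) as the other, a modest move to a lower number is expected in this assay and no move beyond the scatter remains possible. The expected step is a 1.2-fold lower number from compound 2 to compound 4 (0.09 log units; within the scatter) on this estimate. Compound 4 is estimated at 18000 nM with an expected range from 7000 nM to 45000 nM for now.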

Compound 4, half-maximal cytotoxic concentration: 32000 nM
Compound 4: the middle estimate sits 1.8-fold (0.25 log units) below what was measured; the measured number falls inside the stated range.
By their numbers in this assay, from the lowest: compounds 2, 3 and 4 (each within the scatter of the next). At a limit, above all of these: compound 1.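

In this assay, propyl in place of hydrogen on the amide-type nitrogen gives a 1.5-fold higher number from compound 2 to compound 4 (0.16 log units; within the scatter). Among the compounds shown here, the earlier steps changed only the chain, so this is the first reading at the nitrogen itself: with the amide hydrogen replaced by propyl, the number for compound 4 stays within the scatter of that for compound 2. The only limit among the compounds shown belongs to compound 1, and it is a limit of the assay rather than a number: the limit of > 50000 nM in this assay, at which 1 of the 4 values shown sits.

A single substituent at this nitrogen cannot show whether a longer chain, a phenyl ring, an amine or a carboxylic acid there would also leave this assay unmoved. From the compounds shown here alone, it also remains open whether propyl behaves the same way on the butyl-linked chain of compound 1 or the hexyl-linked chain of compound 3.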